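This account rests on a few compounds, and the source may have more. Where it says the series, first, only, none or still open, it means among the compounds named here.

Compound 1, `C(=C/c1ccccc1OCCCCN1CCCC1)\c1ccccc1`: 42.9%
Compound 2, `CCCN1CCN(CCCCOc2ccccc2/C=C/c2ccccc2)CC1`: 42.9%
Compound 3, `CC(=O)N1CCN(CCCCOc2ccccc2/C=C/c2ccccc2)CC1`: 0%

All three compounds were tested in a functional assay on the whole organism with Mus musculus as the target, in the maximal electroshock model, at a dose of 50 mg/kg by the oral route; on this read-out higher numbers stand for more inhibition at the one dose given (going by the name of the read-out) and lower numbers for less inhibition. Compound 3 stands lowest of the three numbers: the step of a number 42.9 percentage points lower from compound 1 to compound 3 (beyond the scatter) and the step of a number 42.9 percentage points lower from compound 2 to compound 3 (beyond the scatter) are both large and beyond the scatter, while compound 1 and compound 2 sit within the scatter of each other, as no change at the digits printed from compound 1 to compound 2 (within the scatter) shows.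

Compound 4, `CC1CCCN(CCCCOc2ccccc2/C=C/c2ccccc2)C1`, has not yet been tested. It differs from compound 3 in one place:

3-methylpiperidin-1-yl in place of 4-acetylpiperazin-1-yl on a saturated chain carbon, four bonds along the chain from an oxygen on an aromatic ring

The two steps that bear on this change are those that brought the 4-acetylpiperazin-1-yl group in, and each cost a large drop in this assay. Compound 4 removes that group again and carries a ring amine without acetyl, as compound 1 and compound 2 do, and both of those gave the higher number. A large upward step from compound 3 to compound 4 is therefore expected, roughly undoing the loss seen in a number 42.9 percentage points lower from compound 1 to compound 3 (beyond the scatter).

Compound 4 is expected to give about 40% in this assay, within an estimated range from 15% to 65%. This estimate means an expected step of a number 40 percentage points higher from compound 3 to compound 4 (beyond the scatter).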

Compound 4, a percentage reported as inhibition, in the whole organism at one dose (the size of the read-out at that dose, not a potency): 12.5%
The estimate for compound 4 lay 27.5 percentage points above the measured number; measured number outside the range, below it.
By their numbers in this assay, from the lowest: compound 3; then compound 4; then compounds 1 and 2 (each within the scatter of the next).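

Taking away the 4-acetylpiperazin-1-yl group does not by itself bring back the higher read-out in this assay: the 3-methylpiperidin-1-yl group gives only a number 12.5 percentage points higher from compound 3 to compound 4 (beyond the scatter), a modest gain. The same group also falls well short of the other two ring amines at this place, on a saturated chain carbon, four bonds along the chain from an oxygen on an aromatic ring, with a number 30.4 percentage points lower from compound 2 to compound 4 (beyond the scatter) and a number 30.4 percentage points lower from compound 1 to compound 4 (beyond the scatter), so a ring amine without acetyl is no guarantee of the higher number in these compounds, and compound 4 is the one that shows this. Nothing available here explains why these ring amines differ.

On these data alone, it remains open whether the drop belongs to the methyl group or to the ring that carries it, which a plain piperidin-1-yl group could help to separate. A morpholin-4-yl group or an open-chain amine such as diethylamino at the same place would show how far this sensitivity to the amine extends.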